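The compounds below may be only part of what the source reports. "The series", "measured", "known", "first", "only" and "open" are said of these compounds alone.

Working notes on the series. Compound 1 `COCCOCCOCCOCCOCC(=O)Oc1c(C(C)C)cccc1C(C)C` carries the longest chain on the shared core, and in an ADME assay on A549 cells (Homo sapiens) for cytotoxicity, read by MTT assay, with a stated time of 24 h (on this read-out higher numbers stand for an effect only at larger amounts of compound and lower numbers for an effect already at smaller amounts), compound 1 gives 630000 nM. Among the measured compounds shown here, compound 3 `COCCOCCOCC(=O)Oc1c(C(C)C)cccc1C(C)C` carries a shorter chain, and in this assay compound 3 gives 4150000 nM; the step of a 6.6-fold higher number from compound 1 to compound 3 (0.82 log units; beyond the scatter) is the single measured step in the set. Compound 2 `COCCOCCOC(=O)Oc1c(C(C)C)cccc1C(C)C` reaches only the assay limit (the limit of > 10000000 nM in this assay, at which 1 of the 3 values shown sits). In this assay compound 2 gives > 10000000 nM, which is a limit and not a number, so compound 2 stands at the top of the numbers shown without a measured place among them. Compound 4 `COCCOCCOCCOCCOC(=O)Oc1c(C(C)C)cccc1C(C)C` differs from compound 2 by (2-methoxyethoxy)methyl in place of hydrogen on a saturated chain carbon bound to an oxygen on a saturated carbon. This is the reverse of the change from compound 1 to compound 3, so the step of a 6.6-fold higher number from compound 1 to compound 3 (0.82 log units; beyond the scatter) bears on it run backwards, and a lower number of about that size is expected in this assay; compound 2 sits at a limit, so the starting point is itself uncertain. Compound 4 is therefore expected at 3000000 nM in this assay, within 800000 nM to 20000000 nM, meaning an expected step of an at least 3.3-fold lower number from compound 2 to compound 4 (0.52 log units; beyond the scatter).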

Compound 4, half-maximal effective concentration: 1360000 nM
For compound 4 the middle estimate is 2.2-fold (0.34 log units) above the measured one; the measured number falls inside the stated range.
By their numbers in this assay, from the lowest: compound 1; then compound 4; then compound 3. At a limit, above all of these: compound 2.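

In this assay, (2-methoxyethoxy)methyl in place of hydrogen on a saturated chain carbon bound to an oxygen on a saturated carbon gives an at least 7.3-fold lower number from compound 2 to compound 4 (0.86 log units; beyond the scatter), so the link between this change and a lower number now holds on a second core. For compound 2, > 10000000 nM is a limit of the assay and not a number, so this step has a lower bound only. The two steps point the same way, but their sizes cannot be separated: the same change on two cores in this assay, a 6.6-fold higher number (0.82 log units; beyond the scatter) from compound 1 to compound 3 and an at least 7.3-fold higher number (0.86 log units; beyond the scatter) from compound 4 to compound 2; the limit leaves it open whether they differ

The compounds shown leave open where compound 2 truly lies and whether a longer chain at this place would lower the number further. They also leave open whether an amine or a carboxylic acid in place of (2-methoxyethoxy)methyl would give a step of similar size or direction.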